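This account rests on a few compounds, and the source may have more. Where it says the series, first, only, none or still open, it means among the compounds named here.

In an ADME assay on HEK293 cells (Homo sapiens) for cytotoxicity, read by reporter gene assay and resazurin assay, with a stated time of 48 h (on this read-out higher numbers stand for lower toxicity in this test and lower numbers for higher toxicity in this test), compound 1 (`COc1c(Br)cccc1C(=O)Nc1ccccc1`) gives > 100000 nM as a limit of the assay, not a number. Compound 2 (`O=C(Nc1ccc(Sc2nc3ccccc3s2)c(Cl)c1)c1cccc(Br)c1`) gives > 100000 nM as a limit too. Compound 2 thus stands at the limit of > 100000 nM in this assay, at which 2 of the 2 values shown sit (no number yet separates it from compound 1). Compound 3 (`O=C(Nc1ccc(Sc2nc3ccccc3s2)c(Cl)c1)c1ccccc1O`) carries 2-hydroxyphenyl in place of 3-bromophenyl on a carbonyl carbon. Among the measured compounds shown here, no step between measured compounds is available to size this change in this assay. A moderate step toward lower numbers is expected there, though the reading may well stay at the limit. The estimated at least 2.0-fold lower number from compound 2 to compound 3 (0.30 log units; that floor lies within the scatter) is only a tentative figure. For compound 3 the estimate is 50000 nM with a range of 12000 nM to 100000 nM as the expected bounds.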

Compound 3, half-maximal cytotoxic concentration: 64000 nM
Estimate against measurement, compound 3: 1.3-fold (0.11 log units) below; the measured number falls inside the stated range.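

In this assay, among the compounds shown here, compound 3 gives 64000 nM, the first reading that is a number rather than a limit. Placing 2-hydroxyphenyl in place of 3-bromophenyl on a carbonyl carbon gives an at least 1.5-fold lower number from compound 2 to compound 3 (0.19 log units; that floor lies within the scatter), so this position can bring the reading inside the measurable range, although the full size of the step stays unknown. The other compounds give no number to set against it: the limit of > 100000 nM in this assay, at which 2 of the 3 values shown sit.

From the compounds shown here alone, it remains open whether the shift follows from the entering 2-hydroxyphenyl or from the leaving 3-bromophenyl, as one step changes both at once. Also open, going by these compounds, is how the reading would respond to an amine or a carboxylic acid on the ring at this place, and whether any such group would take it further from the limit.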